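The source may report more compounds than this note shows. Statements on the series, on what has been measured and on what is new or still open speak of the compounds shown alone.

Measured so far in a functional assay (Homo sapiens) for inhibition of Nucleic Acid, tested at 100 uM; on this read-out higher numbers stand for more inhibition at the one concentration tested (going by the name of the read-out) and lower numbers for less inhibition:
compound 1 `OCCNc1nccc2c1ncn2C1O[C@H](CO)[C@@H](O)[C@H]1O` gives 0%
compound 2 `[N-]=[N+]=Nc1nccc2c1ncn2[C@H]1C[C@H](O)[C@@H](CO)O1` gives 4%
compound 3 `CC1OC(n2cnc3c(N)nccc32)CC1O` gives 3%

The three numbers all lie within the usual scatter of one another, so compound 1 is not separable from compound 2 or compound 3, and no ranking among them can be drawn. None of the three shows inhibition worth noting in this assay.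

Compound 4 `OC[C@H]1OC(n2cnc3c(S)nccc32)[C@H](O)[C@@H]1O` has not yet been measured. It differs from compound 1 in one place: sulfanyl in place of (2-hydroxyethyl)amino on an aromatic carbon. Among the measured compounds shown here, no step between measured compounds is available to calibrate such a change. With every measured value of the series sitting at the floor of the read-out, the expected step is a number 3 percentage points higher from compound 1 to compound 4 (within the scatter), that is, none beyond the scatter. Compound 4 is accordingly estimated at 3%, in a range from -8% to 15%.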

Compound 4, a percentage reported as inhibition, at one concentration (the size of the read-out at that concentration, not a potency): 6%
The estimate for compound 4 lay 3 percentage points below the measured number; low and high end bracket the measured number.
By their numbers in this assay, from the lowest: compounds 1, 3, 2 and 4 (each within the scatter of the next).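

In this assay sulfanyl in place of (2-hydroxyethyl)amino on an aromatic carbon gives a number 6 percentage points higher from compound 1 to compound 4 (within the scatter) and so does not separate the two compounds. Among the compounds shown here, this is the first step read at this position: exchanging the whole (2-hydroxyethyl)amino chain for a single sulfur atom leaves inhibition at the level of the other compounds. No measurement on hand bears on why this is so.

As far as these compounds go, whether a carboxylic acid or a longer alkylamine chain on this carbon would give inhibition beyond the scatter remains open.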